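Fluoro to Methyl on the Aryl Ring of a Succinimide

This account rests on a few compounds, and the source may have more. Where it says the series, first, only, none or still open, it means among the compounds named here.

Three measured compounds and their values in a functional assay on the whole organism (strain Swiss) with Mus musculus as the target, in the maximal electroshock model, with a stated time of 0.25 h, at a dose of 300 mg/kg by the intraperitoneal route; on this read-out lower numbers stand for a weaker effect and higher numbers for a stronger effect at the one dose given:
compound 1 `CCC(C(=O)N1CCN(c2cccc(F)c2)CC1)N1C(=O)CCC1=O` gives 75%;
compound 2 `CC(C(=O)N1CCN(c2ccccc2C(F)(F)F)CC1)N1C(=O)CCC1=O` gives 100%;
compound 3 `CC(C(=O)N1CCN(c2cccc(F)c2)CC1)N1C(=O)CCC1=O` gives 100%.

Compound 1 stands lowest of the three, with compound 2 and compound 3 both above it beyond the scatter. For the measured compounds named here, the only step measured so far, a number 25 percentage points higher from compound 1 to compound 3 (beyond the scatter), concerns a saturated chain carbon and not the aromatic ring. Compound 4 `CCC(C(=O)N1CCN(c2cccc(C)c2)CC1)N1C(=O)CCC1=O` differs from compound 1 by methyl in place of fluoro on an aromatic carbon. Going by the values given here, no measured step touches that position, so nothing here points to a change beyond the scatter in this assay. Compound 4 is therefore expected to give about 75%, within a range from 45% to 100%. The step of no change at the digits printed from compound 1 to compound 4 (within the scatter) is estimated as none beyond the scatter.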

Compound 4, a percentage reported as activity, at one dose (the size of the read-out at that dose, not a potency): 100%
Compound 4: the middle estimate sits 25 percentage points below what was measured; the measured number falls inside the stated range.
By their numbers in this assay, from the lowest: compound 1; then compounds 2, 3 and 4 (each within the scatter of the next).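

Methyl in place of fluoro on the aromatic carbon meta to a large group gives a number 25 percentage points higher from compound 1 to compound 4 (beyond the scatter) in this assay and so shows that this ring position can move the read-out. Until now, only the saturated chain carbon had been seen to do so. No measured evidence at hand accounts for this step.

What the compounds shown leave open is whether chloro, methoxy or an amine on the same aromatic carbon would behave like methyl or like fluoro. Also open, going by these compounds, is how the 3-methylphenyl group would read with the shorter chain of compound 3.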